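Methoxy to chloro on the benzyl arm of the piperazine

The source may hold more compounds than are shown below. What is called first, only, known or untested is meant among the compounds shown, and "the series" means these compounds.

Compound 1 `Cn1c(-c2ccc(NC(=O)CN3CCN(c4ccccc4)CC3)cc2)nc(-c2ccccc2)c1-c1ccccc1` is the reference of the pair measured so far: in a functional assay on MCF7 cells (Homo sapiens) for cytotoxicity, read by MTT assay, with a stated time of 24 h, tested at 32 ug/mL (on this read-out lower numbers stand for a weaker effect and higher numbers for a stronger effect at the one concentration tested), compound 1 gives 63.6%. Compound 2 `COc1ccc(CN2CCN(CC(=O)Nc3ccc(-c4nc(-c5ccccc5)c(-c5ccccc5)n4C)cc3)CC2)cc1` carries a 4-methoxybenzyl in place of phenyl on an amine nitrogen in a ring, and in this assay compound 2 gives 17.7%. The step of a number 45.9 percentage points lower from compound 1 to compound 2 (beyond the scatter) is the only one recorded, and it leaves compound 2 as the lowest of the two numbers, with compound 1 its nearest neighbour.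

Compound 3 `Cn1c(-c2ccc(NC(=O)CN3CCN(Cc4ccc(Cl)cc4)CC3)cc2)nc(-c2ccccc2)c1-c1ccccc1` changes compound 2 further out on the same arm: chloro in place of methoxy on an aromatic carbon. Going by the values given here, no measured step touches a substituent on that benzyl ring; the one recorded step exchanges the whole group on the ring nitrogen, so it says nothing about this smaller change, and it supplies no direction. The expectation is therefore a step of a number 4.3 percentage points higher from compound 2 to compound 3 (within the scatter) that stays close to the scatter, in either direction. On that basis compound 3 is estimated at 22% in this assay, with a range of 8% to 45%.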

Compound 3, a percentage reported as activity, at one concentration (the size of the read-out at that concentration, not a potency): 52.8%
Beside the measured number, compound 3's estimate is 30.8 percentage points below it; the measured number lies above the stated range.
By their numbers in this assay, from the lowest: compound 2; then compound 3; then compound 1.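

In this assay the substituent on the benzyl ring carries much of the read-out: chloro in place of methoxy gives a number 35.1 percentage points higher from compound 2 to compound 3 (beyond the scatter), a large change at a site that the earlier pair had not tested on its own. The low value of compound 2 therefore cannot be assigned to the benzyl arm as such, for with 4-chlorobenzyl in place of phenyl on the ring nitrogen the result is a number 10.8 percentage points lower from compound 1 to compound 3 (beyond the scatter) and only a modest loss remains. Nothing at hand accounts for the gap between the chloro and methoxy compounds, and no measurement beyond these cell values bears on it.

On these data alone, with only two substituents on the benzyl ring, it stays open whether methoxy is the exception or chloro is, and an unsubstituted benzyl, a fluoro, a bromo or a dimethylamino group at the same place would help settle this. Also open, as far as these compounds go, is whether 4-chlorophenyl set directly on the ring nitrogen, without the benzyl carbon, would match or exceed compound 1, and each reading here, taken at a single concentration, gives the size of an effect and not a potency.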